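The source may report more compounds than this note shows. Statements on the series, on what has been measured and on what is new or still open speak of the compounds shown alone.

In a functional assay on NCI-H1650 cells (Homo sapiens) for cytotoxicity, read by MTT assay, with a stated time of 48 h (on this read-out higher numbers stand for weaker inhibition and lower numbers for stronger inhibition), compound 3 `Clc1ccnc2cc(OCCCc3ccccc3)ccc12` gives 630 nM, the lowest of the three numbers in hand. Compound 1 `CCCCCCOc1ccc2c(Cl)ccnc2c1` gives 2080 nM in this assay, and compound 2 `CCOc1ccc2c(Cl)ccnc2c1` gives 3340 nM. Compound 4 `Clc1ccnc2cc(OCCc3ccccc3)ccc12` differs from compound 3 by phenyl in place of benzyl on a saturated chain carbon, two bonds along the chain from an oxygen on an aromatic ring, so the aromatic ring is kept and the chain that carries it is one carbon shorter. Going by the values given here, two steps bear on this. The step of a 3.3-fold lower number from compound 1 to compound 3 (0.52 log units; beyond the scatter) and the step of a 5.3-fold lower number from compound 2 to compound 3 (0.72 log units; beyond the scatter) both show that bringing in the aromatic ring gave a modest drop in the number, and compound 4 keeps that ring. The step of a 1.6-fold higher number from compound 1 to compound 2 (0.21 log units; within the scatter), which removes butyl from the chain, stayed within the scatter, so shortening the chain on its own left little trace. For compound 4 the expected step in this assay is therefore small, a 1.3-fold higher number from compound 3 to compound 4 (0.10 log units; within the scatter), with no confident direction beyond the scatter. Compound 4 is accordingly estimated at 800 nM in this assay, within a range from 350 nM to 1800 nM.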

Compound 4, half-maximal inhibitory concentration: 2300 nM
Estimate against measurement, compound 4: 2.9-fold (0.46 log units) below, and the stated range ends below it.
By their numbers in this assay, from the lowest: compound 3; then compounds 1, 4 and 2 (each within the scatter of the next).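

In this assay, going by these compounds alone, the chain that carries the aromatic ring turns out to matter: replacing benzyl with phenyl at this position gives a 3.7-fold higher number from compound 3 to compound 4 (0.56 log units; beyond the scatter) and so removes the advantage that the earlier compounds had linked to the ring. The ring alone therefore does not set a compound apart, since a 1.5-fold lower number from compound 2 to compound 4 (0.16 log units; within the scatter) and a 1.1-fold higher number from compound 1 to compound 4 (0.04 log units; within the scatter) both leave compound 4 within the scatter of the compounds without a ring, and among these four only compound 3, with benzyl at this position, stands apart. The data offer no measurement that explains this difference.

The compounds shown leave open whether a longer chain ending in phenyl would give a lower number than compound 3 or a higher one. They also leave open whether an amine in the chain, or a fluorine on the phenyl ring, would preserve the standing of compound 3.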